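Shifting a Methoxy Group from Compound 1 to Compound 4

This account rests on a few compounds, and the source may have more. Where it says the series, first, only, none or still open, it means among the compounds named here.

Of the compounds shown here, three have been tested in a functional assay on HT-29 cells (Homo sapiens) for antiproliferative activity, read by sulforhodamine B assay, with a stated time of 72 h; on this read-out lower numbers stand for stronger inhibition and higher numbers for weaker inhibition. Compound 1 `COc1cccc(NC(=S)N/N=C/c2ccc3ccccc3n2)c1` gives 82400 nM, the highest number of the three and so the weakest inhibitor among them. Compound 2 `CN(C)C(=S)N/N=C/c1cnc2ccccc2n1` gives 450 nM, and compound 3 `CN(C)C(=S)N/N=C/c1cc2cccnc2s1` gives 13400 nM. Among the measured compounds shown here, both differ from compound 1 in more than one place, so no single step between measured compounds can be read from them.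

The compound now awaiting measurement, compound 4 `COc1ccc(NC(=S)N/N=C/c2ccc3ccccc3n2)cc1`, is built from the same atoms as compound 1, joined differently: 4-methoxyphenyl in place of 3-methoxyphenyl on an amide-type nitrogen. For the measured compounds named here, nothing measured so far speaks to this particular change, since no pair among the tested compounds differs in this way alone. Because compound 1 stands at 82400 nM and the alteration leading to compound 4 is the smallest kind in the set, the step is expected to be modest, quite possibly none beyond the scatter, with only a slight lean toward a lower number: a 1.4-fold lower number from compound 1 to compound 4 (0.14 log units; within the scatter). Compound 4 is therefore estimated at 60000 nM in this assay, within a range from 20000 nM to 150000 nM, and a reading that is only a limit cannot be ruled out at such high concentrations.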

Compound 4, half-maximal inhibitory concentration: 82300 nM
Compound 4: the middle estimate sits 1.4-fold (0.14 log units) below what was measured, within the range that was stated.
By their numbers in this assay, from the lowest: compound 2; then compound 3; then compounds 4 and 1 (each within the scatter of the next).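

In this assay the step that swaps 3-methoxyphenyl for 4-methoxyphenyl on the amide-type nitrogen is a 1.0-fold lower number from compound 1 to compound 4 (0.00 log units; within the scatter) and so the two compounds cannot be told apart on this read-out. Among the compounds shown here, this is the first comparison in the set that differs in one place only, and it shows that, with the rest of the molecule held fixed, these two placements of the methoxy group give matching results: compound 1 gives 82400 nM and compound 4 gives 82300 nM in the same assay. No supporting data bear on why the two agree, so the finding stands as a plain observation.

The compounds shown leave open whether this match would hold for a group other than methoxy, such as a chlorine, an amine or a carboxylic acid, at either of these two placements on the phenyl ring. They also leave open whether a plain phenyl or a short alkyl chain on the same amide-type nitrogen would give a number clearly apart from these two.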